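The source may report more compounds than this note shows. Statements on the series, on what has been measured and on what is new or still open speak of the compounds shown alone.

Measured so far:
- compound 1 (`C/C(=N/O)c1ccc(NC(=O)Cn2nc(C(F)(F)F)nc2N)cc1`) gives 25.6%
- compound 2 (`COc1cc(-c2nc3sc(-c4ccccc4)cn3n2)cc(OC)c1OC`) gives 10%

In a functional assay on UACC-257 cells (Homo sapiens) for inhibition, read by sulforhodamine B assay, with a stated time of 48 h, tested at 10 uM (on this read-out higher numbers stand for more inhibition of growth at the one concentration tested and lower numbers for less inhibition of growth), compound 1 stands highest of these two compounds, and the gap down to compound 2 lies beyond the usual scatter. The next compound to be tested is compound 3 (`C/C(=N/O)c1ccc(NC(=O)Cn2nc(-c3ccccc3)nc2N)cc1`), which keeps the rest of compound 1 but carries phenyl in place of trifluoromethyl on an aromatic carbon. Among the compounds with values here, no pair of measured compounds differs in one place, so nothing yet shows how much such a swap moves the number, or in which direction. The best anchor is therefore compound 1 itself (25.6%). What is expected in this assay is a number 1.6 percentage points lower from compound 1 to compound 3 (within the scatter) (no shift beyond the scatter, though a move either way is possible). For compound 3 the estimated value is 24% (expected range 8% to 45%).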

Compound 3, percent growth inhibition at one concentration: 34%
For compound 3 the middle estimate is 10 percentage points below the measured one; measured number inside the range.
By their numbers in this assay, from the lowest: compound 2; then compounds 1 and 3 (each within the scatter of the next).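

In this assay, within the data shown here, the swap of phenyl in place of trifluoromethyl on this aromatic carbon gives a number 8.4 percentage points higher from compound 1 to compound 3 (within the scatter), the first comparison here between two compounds that differ in one place. It shows that this carbon, which lies between two ring nitrogen atoms, can carry a ring in place of the small trifluoromethyl group without a loss of growth inhibition beyond the scatter. Compound 1 and compound 3 cannot be told apart on this read-out, and no measurement shown here explains why these two groups read alike.

Still open, going by these compounds, is whether a group of another kind on this carbon, such as an amine, a carboxylic acid or a longer alkyl chain, would move the number beyond the scatter. Also open, on these data alone, is what a phenyl ring bearing a methoxy group would do here.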